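This account rests on a few compounds, and the source may have more. Where it says the series, first, only, none or still open, it means among the compounds named here.

In a functional assay on MCF7 cells (Homo sapiens) for inhibition, read by MTT assay, with a stated time of 3 days (a lower number here means a stronger inhibitor, a higher number a weaker inhibitor), compound 1 `COc1ccccc1/C=C/CCCOc1cc(/C=C\c2cc(OC)c(OC)c(OC)c2)ccc1OC` gives 21000 nM, compound 2 `COc1cccc(/C=C/CCCOc2cc(/C=C\c3cc(OC)c(OC)c(OC)c3)ccc2OC)c1` gives 41000 nM and compound 3 `COc1ccc(/C=C/CCCOc2cc(/C=C\c3cc(OC)c(OC)c(OC)c3)ccc2OC)cc1` gives 16000 nM. Two steps fix the place of compound 3: a 1.3-fold lower number from compound 1 to compound 3 (0.12 log units; within the scatter), and a 2.6-fold lower number from compound 2 to compound 3 (0.41 log units; beyond the scatter). Compound 4 `COc1ccc(/C=C\c2cc(OC)c(OC)c(OC)c2)cc1OCCC/C=C/c1ccc(Br)cc1` differs from compound 3 by bromo in place of methoxy on an aromatic carbon, para to a large group. Among the measured compounds shown here, no measured step replaces the methoxy group itself. The available steps only relocate it, and they stay small: a 2.0-fold higher number from compound 1 to compound 2 (0.29 log units; within the scatter), with the modest step to compound 3 the largest. On that limited basis, no shift beyond the scatter is expected, in either direction. The expected change is a 1.3-fold higher number from compound 3 to compound 4 (0.10 log units; within the scatter). Compound 4 is estimated at 20000 nM, with an expected range of 8000 nM to 50000 nM.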

Compound 4, half-maximal inhibitory concentration: 37000 nM
Estimate against measurement, compound 4: 1.9-fold (0.27 log units) below, and the stated range covers the measured number.
By their numbers in this assay, from the lowest: compounds 3, 1, 4 and 2 (each within the scatter of the next, the first and the last beyond it).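

In this assay, replacing the methoxy group itself on this aromatic carbon, para to a large group, brings a modest rise in the number, beyond the scatter (a 2.3-fold higher number from compound 3 to compound 4 (0.36 log units; beyond the scatter)). The 4-bromophenyl group cannot be told apart from the 2-methoxyphenyl group (a 1.8-fold higher number from compound 1 to compound 4 (0.25 log units; within the scatter)) or the 3-methoxyphenyl group (a 1.1-fold lower number from compound 2 to compound 4 (0.04 log units; within the scatter)), so only the 4-methoxyphenyl comparison separates bromo. Nothing available explains the shift.

Open: whether a hydroxy group, an amine or a carboxylic acid at this place would follow bromo or methoxy.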